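A few compounds are considered here, and "the series" means these few. Any claim that something is new, unique, unknown or untested is made for them only; others in the source may bear on it.

In a functional assay on RS4-11 cells (Homo sapiens) for inhibition, read by CCK-8 assay, with a stated time of 48 h (on this read-out lower numbers stand for stronger inhibition and higher numbers for weaker inhibition), compound 1 (`COc1ccc(NC(=O)NCCNS(=O)(=O)c2ccc(-c3ccccc3OCc3ccccc3)s2)cc1`) gives > 20000 nM, which is a limit of the assay and not a number. Compound 3 (`O=C(NCCNS(=O)(=O)c1ccc(-c2ccccc2OCc2ccccc2)s1)Nc1cccc([N+](=O)[O-])c1`) gives > 20000 nM, which is also a limit. Compound 2 (`O=[N+]([O-])c1ccc(NC(=S)NCCNS(=O)(=O)c2ccc(-c3ccccc3OCc3ccccc3)s2)cc1`) gives 11300 nM. Compound 4 (`COc1ccc(NC(=O)NCCNS(=O)(=O)c2ccc(-c3ccccc3Oc3ccc([N+](=O)[O-])c([N+](=O)[O-])c3)s2)cc1`) differs from compound 1 in one group: 3,4-dinitrophenyl in place of benzyl on an oxygen on an aromatic ring. In words, 3,4-dinitrophenyl stands in place of benzyl on an oxygen on an aromatic ring. The measured steps are an at least 1.7-fold lower number from compound 1 to compound 2 (0.24 log units; that floor lies within the scatter), a step that the two limits leave unreadable from compound 1 to compound 3 and an at least 1.7-fold higher number from compound 2 to compound 3 (0.24 log units; that floor lies within the scatter). All three keep the benzyl, so none gives a direct size for this change. The expected step is therefore an at least 1.6-fold lower number from compound 1 to compound 4 (0.22 log units; that floor lies within the scatter), and no step beyond the scatter can be firmly expected. For compound 4 the estimated value is 12000 nM, with an expected range of 3000 nM to 30000 nM.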

Compound 4, half-maximal inhibitory concentration: 1400 nM
For compound 4 the middle estimate is 8.6-fold (0.93 log units) above the measured one; measured number below the stated range.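

Swapping the group on this oxygen has a real effect: 3,4-dinitrophenyl in place of benzyl gives an at least 14-fold lower number from compound 1 to compound 4 (1.15 log units; beyond the scatter). Within the data shown here, the steps among compound 1, compound 2 and compound 3 lay within the scatter or could not be read, so this is the first clear change in the set. The step is printed only as a floor because compound 1 sits at a limit of the assay: the limit of > 20000 nM in this assay, at which 2 of the 4 values shown sit.

As far as these compounds go, compound 4 changes the ring, its nitro groups and the link to the oxygen all at once, so their separate shares stay open. Plain phenyl or 4-nitrophenyl on this oxygen would be needed to separate them.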